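Carbamoyl to carboxy on the fastest-cleared compound

A few compounds are considered here, and "the series" means these few. Any claim that something is new, unique, unknown or untested is made for them only; others in the source may bear on it.

In an ADME assay on microsomes (Mus musculus) for metabolic stability (on this read-out higher numbers stand for fast clearance and lower numbers for slow clearance), compound 1 (`CNC(=O)[C@@H]1CCCN1S(=O)(=O)c1ccc(Cl)c(COc2cccc3c(-n4ccnc4)cc(C)nc23)c1Cl`) gives 267 mL/min/kg and compound 2 (`CNC(=O)[C@@H]1CCCN1S(=O)(=O)c1ccc(Cl)c(COc2cccc3c(C(F)(F)F)cc(C)nc23)c1Cl`) gives 1380 mL/min/kg as its clearance. Compound 3 (`Cc1cc(C(F)(F)F)c2cccc(OCc3c(Cl)ccc(S(=O)(=O)N4CCC[C@H]4C(N)=O)c3Cl)c2n1`) stands highest of the three at 12600 mL/min/kg on this scale, beyond the scatter from both others. Compound 4 (`Cc1cc(C(F)(F)F)c2cccc(OCc3c(Cl)ccc(S(=O)(=O)N4CCC[C@H]4C(=O)O)c3Cl)c2n1`) differs from it in one place (hydroxy in place of amino on a carbonyl carbon), with hydroxy in place of amino on a carbonyl carbon.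

Among the measured compounds shown here, no measured step makes this exchange. The closest is a 9.1-fold higher number from compound 2 to compound 3 (0.96 log units; beyond the scatter) for hydrogen in place of methyl on an amide-type nitrogen, the same nitrogen that now leaves. The other, a 5.2-fold higher number from compound 1 to compound 2 (0.71 log units; beyond the scatter) for trifluoromethyl in place of 1H-imidazol-1-yl, lies elsewhere and bears on it less. The data do not fix a direction, but with compound 3 at the top of the three numbers, a lower number seems likelier. The expected change is a 5.0-fold lower number from compound 3 to compound 4 (0.70 log units; beyond the scatter) as an estimate, a modest step of similar size. For compound 4 the estimated clearance is 2500 mL/min/kg with a range of 400 mL/min/kg to 12000 mL/min/kg as the expected span.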

Compound 4, clearance: 13.3 mL/min/kg
For compound 4 the middle estimate is 190-fold (2.27 log units) above the measured one; the whole stated range lies above it.
By their numbers in this assay, from the lowest: compound 4; then compound 1; then compound 2; then compound 3.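

In this assay, the carbonyl carbon on the saturated ring turns out to be the most sensitive place among those shown: hydroxy in place of amino gives a 950-fold lower number from compound 3 to compound 4 (2.98 log units; beyond the scatter) and hydroxy in place of methylamino gives a 100-fold lower number from compound 2 to compound 4 (2.02 log units; beyond the scatter) in the same direction. Both steps are large, whereas the earlier exchanges were modest, and they run opposite to the rise seen on removing the methyl from the amide-type nitrogen, so changes at this one carbonyl group move the number both up and down. Nothing available here accounts for the size of the drop.

The compounds shown leave open whether the low number needs the free carboxylic acid, or whether a methyl ester or a tetrazole in its place would keep it. They also leave open whether 1H-imidazol-1-yl in place of trifluoromethyl would still shift the number in the presence of the carboxy group.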